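The compounds below may be only part of what the source reports. "The series", "measured", "known", "first", "only" and "open" are said of these compounds alone.

Measured compounds:
compound 1 `CCOc1nc(N)nc2c1ncn2/C=C1/CC1(CO)CO` gives > 300000 nM in an ADME assay on HFF cells (Homo sapiens) for cytotoxicity, with a stated time of 8 days; a higher number here means that more compound is tolerated, a lower number that less compound is tolerated; this is a limit of the assay, not a number
compound 2 `Nc1nc(OCc2ccccc2)c2ncn(/C=C3/CC3(CO)CO)c2n1` gives > 300000 nM; also a limit
compound 3 `CCCSc1nc(N)nc2c1ncn2/C=C1/CC1(CO)CO` gives > 300000 nM; also a limit

Compound 1 therefore has no number in this assay, only a limit, and the same holds for the two other compounds shown: all three values sit at one point, (the limit of > 300000 nM in this assay, at which 3 of the 3 values shown sit). The three measured steps that connect them, a step that the two limits leave unreadable from compound 1 to compound 2, a step that the two limits leave unreadable from compound 1 to compound 3 and a step that the two limits leave unreadable from compound 2 to compound 3, cannot be read in size or direction, because the limit of > 300000 nM in this assay, at which 3 of the 3 values shown sit, covers both ends of each.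

Compound 4 `CC(C)CNc1nc(N)nc2c1ncn2/C=C1/CC1(CO)CO` is not yet measured. It differs from compound 1 in one place: isobutylamino in place of ethoxy on an aromatic carbon. Among the compounds with values here, the steps that bear on it are those starting from compound 1 and from the other two, and none of them yields a readable size. No step beyond the scatter can therefore be expected in either direction, and the expectation is that compound 4 behaves like the three measured compounds and again reaches the limit, (the limit of > 300000 nM in this assay, at which 3 of the 3 values shown sit).

On that basis compound 4 is estimated at 300000 nM, with a range from 100000 nM to 1000000 nM, which means an expected step of a number no higher from compound 1 to compound 4 (the limit leaves the size open).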

Compound 4, half-maximal cytotoxic concentration: > 300000 nM
Compound 4 ended at the assay's limit; the forecaster's own chance of this, stated with the estimate: 85%; the middle value sits exactly at the limit.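

In this assay compound 4 gives > 300000 nM, a limit and not a number. The steps from compound 1, compound 2 and compound 3 to compound 4 cannot be read in size or direction, because both ends of each sit at one point: the limit of > 300000 nM in this assay, at which 4 of the 4 values shown sit.

The compounds shown leave open at what concentration any of the four becomes cytotoxic, and whether the groups on the aromatic carbon differ at all in this assay.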